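A ring swap on the amide of compound 1

The source may hold more compounds than are shown below. What is called first, only, known or untested is meant among the compounds shown, and "the series" means these compounds.

Compound 1 `CC(C)n1ncc2c(C(=O)Nc3c(F)cccc3F)cc(-c3cccs3)nc21` gives > 200000 nM (a limit)
Compound 2 `CC(C)n1ncc2c(C(=O)N3CCc4cc(F)ccc43)cc(-c3cccs3)nc21` gives > 200000 nM (a limit)
Compound 3 `CC(C)n1ncc2c(C(=O)Nc3ccccn3)cc(-c3ccccc3)nc21` gives 12500 nM

Compound 1 gives > 200000 nM in an ADME assay on LLC-MK2 cells (Macaca mulatta) for cytotoxicity, read by spectrophotometry and crystal violet staining, with a stated time of 4 days (a higher number here means that more compound is tolerated, a lower number that less compound is tolerated), and this is a limit of the assay, not a number. Compound 2 gives the same limit. Compound 4 `CC(C)n1ncc2c(C(=O)Nc3ccncc3)cc(-c3cccs3)nc21` carries pyridin-4-yl in place of 2,6-difluorophenyl on an amide-type nitrogen. Among the compounds with values here, no measured pair isolates this change, so the size of the step is uncertain. Within the data shown here, the only real number comes from compound 3, which gives 12500 nM with a hetero atom in the ring on its amide, though it also differs from compound 1 elsewhere. A fall in the tolerated concentration is therefore expected, with an at least 3.3-fold lower number from compound 1 to compound 4 (0.52 log units; beyond the scatter) as the estimated step. The expected value for compound 4 is 60000 nM (range 15000 nM to 200000 nM).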

Compound 4, half-maximal cytotoxic concentration: 6300 nM
Compound 4: the middle estimate sits 9.5-fold (0.98 log units) above what was measured; measured number outside the range, below it.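

In this assay, pyridin-4-yl in place of 2,6-difluorophenyl on the amide nitrogen gives an at least 31-fold lower number from compound 1 to compound 4 (1.50 log units; beyond the scatter) with the rest of the molecule unchanged, so this single swap is enough to lower the tolerated concentration. Compound 3 could not show this, as it also differs from compound 1 elsewhere. The value for compound 1 is a limit, so the step gives only a minimum size: the limit of > 200000 nM in this assay, at which 2 of the 4 values shown sit.

The swap removes both fluorines and adds a ring nitrogen at once, and the compounds shown do not separate these two changes. Plain phenyl or pyridin-3-yl on the same amide nitrogen would begin to do so.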